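From Cyclopropylamino to Phenoxy: a Single Swap

The source may hold more compounds than are shown below. What is called first, only, known or untested is meant among the compounds shown, and "the series" means these compounds.

Compound 1, `NC(N)=NC(=O)c1nc(Cl)c(NC2CC2)nc1N`, is the starting point here. In an assay for inhibition of acid-sensing ion channel 3 (Homo sapiens), read by patch clamp, tested at 1 uM (a higher number here means more inhibition at the concentration tested (going by the name of the read-out), a lower number less inhibition), compound 1 is recorded as "not determined" (no result reported), so its standing can only be described through its neighbours. Two related compounds do carry numbers. Compound 2, `NC(N)=NC(=O)c1nc(Cl)c(Nc2ccc(C(F)(F)F)cc2)nc1N`, gives 50% in this assay. Compound 3, `NC(N)=NC(=O)c1nc(Cl)c(NCc2ccccc2F)nc1N`, gives 26% in this assay. Both share the core of compound 1 and differ from it in the group attached at one aromatic carbon of that core: in compound 2 an aryl amine bearing a trifluoromethyl, in compound 3 a benzylamine carrying a fluorine.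

Compound 4, `NC(N)=NC(=O)c1nc(Cl)c(Oc2ccccc2)nc1N`, is the compound still to be measured. It differs from compound 1 in one place: phenoxy in place of cyclopropylamino on an aromatic carbon. The swap keeps an aromatic ring at that carbon, as in compounds 2 and 3, but links it through an oxygen rather than a nitrogen with its hydrogen.

For the measured compounds named here, without a value for compound 1, no step from compound 1 to compound 4 can be sized, and no direction can be given in this assay. The expectation for compound 4 rests on compounds 2 and 3 alone and sits between them. Compound 4 is expected to give 32% in this assay, within a range from 10% to 55%.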

Compound 4, a percentage reported as inhibition, at one concentration (the size of the read-out at that concentration, not a potency): 23%
Beside the measured number, compound 4's estimate is 9 percentage points above it, and the stated range covers the measured number.
By their numbers in this assay, from the lowest: compounds 4 and 3 (each within the scatter of the next); then compound 2.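

With compound 1 recorded in this assay as "not determined" (no result reported), the swap to compound 4 cannot be sized, and no other pair among these compounds differs in only one place. No measured property bears on this result. Left open is whether phenoxy in place of cyclopropylamino raises inhibition, lowers it, or leaves it unchanged.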